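Moving the halogen around the terminal phenoxy ring

The source may report more compounds than this note shows. Statements on the series, on what has been measured and on what is new or still open speak of the compounds shown alone.

Of the compounds shown here, two sharing one core have been measured in an assay on cells for activation of probable G-protein coupled receptor 34 (Mus musculus), with a stated time of 1 h; a higher number here means a larger maximal response, a lower number a smaller maximal response. Compound 1 `Cc1ccccc1Oc1cccc(COc2ccccc2CCC(=O)OCCCOP(=O)(O)OC[C@H](N)C(=O)O)c1` gives 0.28. Going by the values given here, compound 2 `N[C@@H](COP(=O)(O)OCCCOC(=O)CCc1ccccc1OCc1cccc(Oc2ccccc2Cl)c1)C(=O)O` gives 0.069, the lowest of the two numbers; the only step between them, a number 0.21 lower from compound 1 to compound 2 (beyond the scatter), is beyond the scatter and modest in size. Compound 3 `N[C@@H](COP(=O)(O)OCCCOC(=O)CCc1ccccc1OCc1cccc(Oc2ccc(Br)cc2)c1)C(=O)O` is not yet measured. It differs from compound 2 by 4-bromophenyl in place of 2-chlorophenyl on an oxygen on an aromatic ring. Among the compounds with values here, no measured step involves this exact change: the single step seen swaps chloro for methyl at one aromatic carbon, whereas here both the halogen and its place on the ring change. That step therefore offers only loose guidance, and compound 2 already sits low on the scale. Compound 3 is expected to give a small rise or none beyond the scatter, a number 0.051 higher from compound 2 to compound 3 (within the scatter), and its value is estimated at 0.12, within 0.03 to 0.3.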

Compound 3, intrinsic activity: the largest response reached, as a fraction of the reference agonist's: 0.97
Beside the measured number, compound 3's estimate is 0.85 below it; the whole stated range lies below it.
By their numbers in this assay, from the lowest: compound 2; then compound 1; then compound 3.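

Swapping the terminal group on the oxygen on an aromatic ring can move the maximal response in this assay far more than the chloro-for-methyl step suggested: 4-bromophenyl in place of 2-chlorophenyl gives a number 0.90 higher from compound 2 to compound 3 (beyond the scatter), and 4-bromophenyl in place of 2-methylphenyl gives a number 0.69 higher from compound 1 to compound 3 (beyond the scatter). Both of these steps are large, so this position is not limited to the low responses seen with the 2-chlorophenyl and 2-methylphenyl groups. No measured evidence accounts for the rise.

The bromine and its place on the ring change together in both steps, so the compounds shown cannot say which of the two carries the effect. A 4-chlorophenyl or a 2-bromophenyl group would separate them, and an unsubstituted phenyl group would show what the ring does without any substituent.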